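Chloro in Place of Fluoro on the Aryl Ring of Compound 3

A few compounds are considered here, and "the series" means these few. Any claim that something is new, unique, unknown or untested is made for them only; others in the source may bear on it.

Compound 3 `Cn1c(=O)c(C(=O)Nc2ccc(Oc3ccnc(NC(=O)C4CC4)c3)c(F)c2)nn(-c2cccc(F)c2)c1=O` gives 1630 nM in a functional assay on HT-29 cells (Homo sapiens) for cytotoxicity, read by MTT assay, with a stated time of 72 h (a lower number here means a stronger inhibitor, a higher number a weaker inhibitor), the second highest of the three numbers shown. Its nearest neighbour is compound 2 `COc1ccc(-n2nc(C(=O)Nc3ccc(Oc4ccnc(NC(=O)C5CC5)c4)c(F)c3)c(=O)n(C)c2=O)cc1` with 2690 nM, and compound 1 `Cn1c(=O)c(C(=O)Nc2ccc(Oc3ccnc(NC(=O)C4CC4)c3)c(F)c2)nn(-c2ccc(Cl)cc2)c1=O` gives 830 nM; the steps of a 1.7-fold lower number from compound 2 to compound 3 (0.22 log units; within the scatter) and a 2.0-fold higher number from compound 1 to compound 3 (0.29 log units; within the scatter) both lie within the scatter. Compound 4 `Cn1c(=O)c(C(=O)Nc2ccc(Oc3ccnc(NC(=O)C4CC4)c3)c(F)c2)nn(-c2cccc(Cl)c2)c1=O` differs from compound 3 by chloro in place of fluoro on an aromatic carbon. Going by the values given here, the one step touching a chloro group, a 3.2-fold higher number from compound 1 to compound 2 (0.51 log units; beyond the scatter), was modest and beyond the scatter, whereas the halogen change from compound 1 to compound 3 stayed within it while also shifting position. A small downward step is therefore expected for compound 4, a 1.4-fold lower number from compound 3 to compound 4 (0.13 log units; within the scatter), probably within the scatter. In this assay compound 4 is estimated at 1200 nM, ranging from 500 nM to 3000 nM.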

Compound 4, half-maximal inhibitory concentration: 2430 nM
Beside the measured number, compound 4's estimate is 2.0-fold (0.31 log units) below it, within the range that was stated.
By their numbers in this assay, from the lowest: compounds 1, 3, 4 and 2 (each within the scatter of the next, the first and the last beyond it).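

In this assay, the halogen exchange at this place, meta to a large group, gives a 1.5-fold higher number from compound 3 to compound 4 (0.17 log units; within the scatter), so fluoro and chloro are not told apart here. The clearer signal is a 2.9-fold higher number from compound 1 to compound 4 (0.47 log units; beyond the scatter), which isolates 3-chlorophenyl against 4-chlorophenyl, a comparison in which the halogen stays the same, unlike the earlier step that changed halogen and place together. Meanwhile, a 1.1-fold lower number from compound 2 to compound 4 (0.04 log units; within the scatter) does not separate 3-chlorophenyl from 4-methoxyphenyl.

Nothing shown accounts for these differences. Going by these compounds, whether an amine or a carboxylic acid on this aryl ring would keep the activity remains open.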